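Cyclopropyl to Furan-2-yl: an Expected Step

The source may report more compounds than this note shows. Statements on the series, on what has been measured and on what is new or still open speak of the compounds shown alone.

Of the compounds shown here, two have been measured in a functional assay on the whole organism (plasma, strain Sprague-Dawley) with Rattus norvegicus as the target, with a stated time of 2 h, at a dose of 50 mg/kg by the oral route; on this read-out lower numbers stand for a weaker effect and higher numbers for a stronger effect at the one dose given. In this assay compound 1 `c1ccc(C(/N=C2\CCCCN2)C2CC2)cc1` gives 33%, and compound 2 `c1ccc(C(/N=C2\CCCCCCN2)C2CC2)cc1` gives 46%. Among the measured compounds shown here, compound 1 therefore stands lowest of the two numbers, and compound 2 lies higher by an amount beyond the usual scatter; no single-point step between the two is recorded, so only their two values are known.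

Compound 3 `c1ccc(C(/N=C2\CCCCN2)c2ccco2)cc1` has not yet been tested in this assay. It differs from compound 1 in one place: furan-2-yl in place of cyclopropyl on a saturated chain carbon bound to an aromatic carbon and a double-bonded nitrogen. For the measured compounds named here, no measured pair in the set carries a change of this kind, so there is no recorded step to lean on. The account expects a small rise or no change beyond the scatter for compound 3 relative to compound 1, a step written as a number 7 percentage points higher from compound 1 to compound 3 (within the scatter). Compound 3 is thus estimated at 40% in this assay, with a range from 20% to 60%, which the measurement will confirm or overturn.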

Compound 3, a percentage reported as inhibition, in the whole organism at one dose (the size of the read-out at that dose, not a potency): 28%
Compound 3: the middle estimate sits 12 percentage points above what was measured, and the stated range covers the measured number.
By their numbers in this assay, from the lowest: compounds 3 and 1 (each within the scatter of the next); then compound 2.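

In this assay, furan-2-yl in place of cyclopropyl on a saturated chain carbon bound to an aromatic carbon and a double-bonded nitrogen gives a number 5 percentage points lower from compound 1 to compound 3 (within the scatter), the first step recorded at this place. It shows that, on the core of compound 1, a five-membered aromatic ring with 1 hetero atom and a hydrogen-bond acceptor can stand where a three-membered non-aromatic ring of carbon only stood, without a change in this read-out that can be told from the scatter. Nothing measured here bears on why the read-out holds across this change.

The compounds shown leave open whether other groups at this place, such as a methyl group, an amine or a carboxylic acid, would move the read-out beyond the scatter, and whether furan-2-yl would give a similar step on the core of compound 2. On these data alone, since this assay reports the size of the effect at a single dose and not a potency, it also remains open whether the two groups would stay this close at other doses or times.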